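Sulfonamide series: from compound 3 to compound 4

The compounds below may be only part of what the source reports. "The series", "measured", "known", "first", "only" and "open" are said of these compounds alone.

Measured so far in a functional assay on Huh-7 cells (Homo sapiens) for inhibition, read by CCK-8 assay, with a stated time of 72 h; a lower number here means a stronger inhibitor, a higher number a weaker inhibitor
compound 1 `O=C(/C=C/c1cccnc1)NCCCCCCCc1ccc(S(=O)(=O)Nc2ccccc2)cc1` gives 1230 nM
compound 2 `O=C(/C=C/c1cccnc1)NCCCCCc1cccc(S(=O)(=O)Nc2ccccc2)c1` gives 41.1 nM
compound 3 `Cc1ccccc1NS(=O)(=O)c1cccc(CCCCCCNC(=O)/C=C/c2cccnc2)c1` gives 0.525 nM

Compound 3 has the lowest number of the three, beyond the scatter from both compound 2 and compound 1. Compound 4 `O=C(/C=C/c1cccnc1)NCCCCCCc1cccc(S(=O)(=O)Nc2ccc(C(F)(F)F)cc2)c1` differs from compound 3 by 4-(trifluoromethyl)phenyl in place of 2-methylphenyl on a sulfonamide nitrogen. For the measured compounds named here, no measured pair isolates this change, so the expectation is tentative: a moderate rise in the number in this assay beyond the scatter. An expected step of a 9.5-fold higher number from compound 3 to compound 4 (0.98 log units; beyond the scatter) is the working figure. Compound 4 is expected at 5 nM with an estimated range of 0.6 nM to 60 nM for this measurement.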

Compound 4, half-maximal inhibitory concentration: 164 nM
For compound 4 the middle estimate is 33-fold (1.52 log units) below the measured one; measured number outside the range, above it.
By their numbers in this assay, from the lowest: compound 3; then compound 2; then compound 4; then compound 1.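

In this assay, for the compounds shown here, the group on the sulfonamide nitrogen carries a large share of the number: 4-(trifluoromethyl)phenyl in place of 2-methylphenyl gives a 310-fold higher number from compound 3 to compound 4 (2.49 log units; beyond the scatter) and is the first change made in one place only. Compounds 1 and 2 offer no such single-place comparison with compound 3. Nothing measured here gives a reason for the size of this step.

Still open, from the compounds shown here alone, is whether the rise follows the trifluoromethyl group, its place on the ring or the loss of the methyl. On the same chain, 4-methylphenyl and 2-(trifluoromethyl)phenyl on this nitrogen would separate these readings.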